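Methoxycarbonyl for methoxy on the aryl group: expected growth inhibition

A few compounds are considered here, and "the series" means these few. Any claim that something is new, unique, unknown or untested is made for them only; others in the source may bear on it.

Measured so far:
compound 1 `NS(=O)(=O)NCCC1CCN(c2cc(-c3ccccc3)ncn2)CC1` gives 66500 nM in a functional assay on HT-29 cells (Homo sapiens) for antiproliferative activity, read by sulforhodamine B assay, with a stated time of 48 h; a higher number here means a weaker inhibitor of growth, a lower number a stronger inhibitor of growth
compound 2 `Cc1ccc(-c2cc(N3CCC(CCNS(N)(=O)=O)CC3)ncn2)cc1` gives 52300 nM in this assay
compound 3 `COc1ccc(-c2cc(N3CCC(CCNS(N)(=O)=O)CC3)ncn2)cc1` gives 72300 nM in this assay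

Compound 3 carries the highest of the three numbers, but neither neighbour is separated from it: a 1.1-fold higher number from compound 1 to compound 3 (0.04 log units; within the scatter) and a 1.4-fold higher number from compound 2 to compound 3 (0.14 log units; within the scatter). Compound 4 `COC(=O)c1ccc(-c2cc(N3CCC(CCNS(N)(=O)=O)CC3)ncn2)cc1` differs from compound 3 by methoxycarbonyl in place of methoxy on an aromatic carbon. The steps measured at this place (a 1.3-fold lower number from compound 1 to compound 2 (0.10 log units; within the scatter), a 1.1-fold higher number from compound 1 to compound 3 (0.04 log units; within the scatter), a 1.4-fold higher number from compound 2 to compound 3 (0.14 log units; within the scatter)) all stay within the scatter, and none of them involves a methoxycarbonyl, so no direct guide exists for this group. On that basis the expected step of a 1.1-fold lower number from compound 3 to compound 4 (0.05 log units; within the scatter) is none beyond the scatter. Compound 4 is therefore estimated at 65000 nM in this assay, with a range from 25000 nM to 170000 nM.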

Compound 4, concentration for 50% growth inhibition: 19600 nM
Estimate against measurement, compound 4: 3.3-fold (0.52 log units) above; the whole stated range lies above it.
By their numbers in this assay, from the lowest: compound 4; then compounds 2, 1 and 3 (each within the scatter of the next).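

Within the data shown here, at this aromatic carbon, para to a large group, methoxycarbonyl is the first change to give steps beyond the scatter in this assay: a 3.7-fold lower number from compound 3 to compound 4 (0.57 log units; beyond the scatter) and a 2.7-fold lower number from compound 2 to compound 4 (0.43 log units; beyond the scatter) and a 3.4-fold lower number from compound 1 to compound 4 (0.53 log units; beyond the scatter). Hydrogen, methyl and methoxy stay within the scatter of one another, so the position does respond to substitution, though only this one group shows it. Nothing measured here explains the shift.

As far as these compounds go, whether the carbonyl or the whole methoxycarbonyl group carries the step remains open. A carboxylic acid, a primary amide or a longer ester at this carbon would separate these.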